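Switching the aryl group on the shared core of compound 1

The compounds below may be only part of what the source reports. "The series", "measured", "known", "first", "only" and "open" are said of these compounds alone.

Compound 1 `Cc1nc(-c2ccsc2)sc1COc1ccc2c(c1)OCC2CC(=O)O` shows 56.5% in a functional assay on CHO cells for agonist activity at Free fatty acid receptor 1 (Homo sapiens), read by FLIPR and calcium flux, tested at 100 nM; a higher number here means a stronger effect of the compound at the concentration tested, a lower number a weaker effect. Compound 2 `Cc1nc(-c2ccccc2Cl)sc1COc1ccc2c(c1)OCC2CC(=O)O` gives 12.4%, the lowest of the two numbers measured, and the step of a number 44.1 percentage points lower from compound 1 to compound 2 (beyond the scatter) marks how much that position matters. Compound 3 `Cc1nc(-c2ccc(C(F)(F)F)cc2)sc1COc1ccc2c(c1)OCC2CC(=O)O` carries a change at the same place: 4-(trifluoromethyl)phenyl in place of 2-chlorophenyl on an aromatic carbon. Within the data shown here, no measured step compares two such six-membered rings, so the direction is open; only the size of the earlier loss suggests that the aryl group weighs heavily. Compound 3 is therefore expected to stay on the weaker side, with an estimated a number 9.6 percentage points higher from compound 2 to compound 3 (within the scatter) to about 22%, in the range 5% to 48%.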

Compound 3, a percentage reported as activity, at one concentration (the size of the read-out at that concentration, not a potency): 50.4%
The estimate for compound 3 lay 28.4 percentage points below the measured number; measured number outside the range, above it.
By their numbers in this assay, from the lowest: compound 2; then compounds 3 and 1 (each within the scatter of the next).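

In this assay, the change of aryl group gives a number 38 percentage points higher from compound 2 to compound 3 (beyond the scatter), so the low number of compound 2 does not extend to every six-membered aromatic ring of carbon only at this place. With 4-(trifluoromethyl)phenyl in place of thiophen-3-yl, there is a number 6.1 percentage points lower from compound 1 to compound 3 (within the scatter), so these two different rings cannot be told apart here. No available evidence bears on this result. The compounds leave open whether the low number of compound 2 follows from the chlorine or from where it sits on the phenyl ring. As far as these compounds go, how a phenyl ring carrying an amine or a carboxylic acid would read also remains open.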